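Replacing the Aryl Group on a Prostaglandin Receptor Antagonist

The compounds below may be only part of what the source reports. "The series", "measured", "known", "first", "only" and "open" are said of these compounds alone.

Three measured compounds share one core and differ only in the group attached to it. Compound 1 `O=C(O)c1csc(-n2nc(-c3ccc(F)cc3)c3ccccc32)n1` carries a 4-fluorophenyl group, and in an assay on isolated protein for antagonist activity at prostaglandin E2 receptor EP1 subtype (Homo sapiens), read by reporter gene assay (a lower number here means a stronger inhibitor, a higher number a weaker inhibitor), compound 1 gives 4.5 nM. Compound 2 `O=C(O)c1csc(-n2nc(-c3ccc(Cl)cc3)c3ccccc32)n1` carries a 4-chlorophenyl group, and in this assay compound 2 gives 12 nM; this is the step of a 2.7-fold higher number from compound 1 to compound 2 (0.43 log units; beyond the scatter). Compound 3 `COc1ccc(-c2nn(-c3nc(C(=O)O)cs3)c3ccccc23)cc1` carries a 4-methoxyphenyl group, and in this assay compound 3 gives 4 nM, the lowest of the three numbers. Its lead over compound 1 is not real, since a 1.1-fold lower number from compound 1 to compound 3 (0.05 log units; within the scatter), whereas the step of a 3.0-fold lower number from compound 2 to compound 3 (0.48 log units; beyond the scatter) is a clear one.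

Compound 4 `O=C(O)c1csc(-n2nc(C3=CCCCC3)c3ccccc32)n1` has not been measured. (cyclohex-1-en-1-yl in place of 4-methoxyphenyl on an aromatic carbon). For the measured compounds named here, none of the measured steps bears directly on this change: each of them only exchanges a small substituent on the aromatic ring and keeps that ring in place, and together they cover a modest range. Here the aromatic ring itself leaves and a non-aromatic ring with one double bond enters, a larger change than anything tested. A weakening beyond the scatter is therefore expected, but with wide uncertainty. Compound 4 is estimated at 25 nM, within 6 nM to 100 nM; the expected step is a 6.3-fold higher number from compound 3 to compound 4 (0.80 log units; beyond the scatter).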

Compound 4, half-maximal inhibitory concentration: 4 nM
For compound 4 the middle estimate is 6.3-fold (0.80 log units) above the measured one; measured number outside the range, below it.
By their numbers in this assay, from the lowest: compounds 3, 4 and 1 (each within the scatter of the next); then compound 2.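

In this assay the aromatic ring at this position proves to be replaceable: the step of no change at the digits printed from compound 3 to compound 4 (within the scatter) and the step of a 1.1-fold lower number from compound 1 to compound 4 (0.05 log units; within the scatter) both stay within the scatter, even though a non-aromatic ring with one double bond has taken the place of the phenyl ring and its substituent. The earlier compounds shown here only exchanged a small substituent on an aromatic ring that stayed in place, so they could not show this, and the step of a 3.0-fold lower number from compound 2 to compound 4 (0.48 log units; beyond the scatter) shows that the new ring also gives a lower number than the 4-chlorophenyl group does. No measurement here offers an explanation for how closely cyclohex-1-en-1-yl matches 4-methoxyphenyl and 4-fluorophenyl.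

The compounds shown do not tell whether the one remaining double bond matters, a question that a fully saturated cyclohexyl group would address. Nor do they tell whether a ring is needed here at all, or how a nitrogen-containing piperidine ring or an open butyl chain would fare at this position.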